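A few compounds are considered here, and "the series" means these few. Any claim that something is new, unique, unknown or untested is made for them only; others in the source may bear on it.

Three closely related esters have been measured in an ADME assay on a cell-free system (plasma, Homo sapiens) for metabolic stability, read by LC-MS; a higher number here means that the compound lasts longer, a lower number that the compound disappears faster. Compound 1 `CCCCOC(=O)c1cccc(-c2cc(C(=O)Nc3ccncc3)ccc2CN)c1` gives 0.367 h, compound 2 `NCc1ccc(C(=O)Nc2ccncc2)cc1-c1cccc(C(=O)OCC2CCCCC2)c1` gives 1.65 h, and compound 3 `CC(C)OCCOC(=O)c1cccc(-c2cc(C(=O)Nc3ccncc3F)ccc2CN)c1` gives 0.1 h, the lowest of the three numbers.

The next compound, compound 4 `NCc1ccc(C(=O)Nc2ccncc2F)cc1-c1cccc(C(=O)OCC2CCCC2)c1`, keeps the core of compound 3 and alters only the ester: cyclopentyl in place of isopropoxymethyl on a saturated chain carbon bound to an oxygen next to a carbonyl group. In words, cyclopentyl takes the place of isopropoxymethyl on a saturated chain carbon bound to an oxygen next to a carbonyl group, turning 2-isopropoxyethyl into cyclopentylmethyl.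

Among the compounds with values here, the only measured step at this place is a 4.5-fold higher number from compound 1 to compound 2 (0.65 log units; beyond the scatter), where cyclohexyl replaced propyl. It is a modest step, beyond the scatter, and it also puts a carbon ring where an open chain stood. The match is imperfect. The chain in compound 1 holds no ether oxygen, and compound 1 and compound 2 lack the fluorine that compound 3 and compound 4 carry. Within the data shown here, no measured pair tests this exact swap.

An upward change of similar size is nevertheless expected, and the estimated step reads a 4.5-fold higher number from compound 3 to compound 4 (0.65 log units; beyond the scatter). Compound 4 is expected to show a half-life of about 0.45 h, with an estimated range from 0.15 h to 1.3 h.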

Compound 4, half-life: 0.283 h
For compound 4 the middle estimate is 1.6-fold (0.20 log units) above the measured one, and the stated range covers the measured number.
By their numbers in this assay, from the lowest: compound 3; then compounds 4 and 1 (each within the scatter of the next); then compound 2.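

In this assay, cyclopentyl in place of isopropoxymethyl gives a 2.8-fold higher number from compound 3 to compound 4 (0.45 log units; beyond the scatter) and so shows that a carbon ring at this saturated chain carbon can go with a longer half-life in compounds carrying the fluorine, and when the group that leaves holds an ether oxygen. The earlier step of a 4.5-fold higher number from compound 1 to compound 2 (0.65 log units; beyond the scatter) also put a carbon ring in place of an open chain, so both steps shown at this position point upward and none among the pairs shown goes against them, though these two pairs differ in the groups exchanged and in the fluorine. No measurement of any other property bears on this rise, which therefore stays unexplained.

Among the compounds shown, the change from 2-isopropoxyethyl to cyclopentylmethyl removes the ether oxygen and adds the ring in a single step, and a plain pentyl chain or a tetrahydropyranyl ring on the fluorine-bearing core would be needed to tell those two changes apart. From the compounds shown here alone, the effect on half-life of an amine or a carboxylic acid on this chain also remains open.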